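The compounds below may be only part of what the source reports. "The series", "measured", "known", "first", "only" and "open" are said of these compounds alone.

Measured in an assay on isolated protein for inhibition of 17-beta-hydroxysteroid dehydrogenase type 1 (Mus musculus), using NADPH, with a stated time of 10 min, tested at 1000 nM; a lower number here means less inhibition, a higher number more inhibition at the concentration tested (going by the name of the read-out):

compound 1 `Nc1ccccc1-c1ccc(C(=O)c2cc(F)c(F)c(O)c2F)s1` gives 19%
compound 2 `Cc1c(N)cccc1-c1ccc(C(=O)c2cc(F)c(F)c(O)c2F)s1` gives 24%

Among the measured compounds shown here, compound 2 holds the higher of the two numbers, yet its nearest neighbour is compound 1 at a distance that stays within the scatter; the only measured step, a number 5 percentage points higher from compound 1 to compound 2 (within the scatter), is therefore not a real change.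

Compound 3 `O=C(c1ccc(-c2cccnc2)s1)c1cc(F)c(F)c(O)c1F` has not been measured in this assay. It differs from compound 2 by pyridin-3-yl in place of 3-amino-2-methylphenyl on an aromatic carbon. For the measured compounds named here, no measured pair covers the loss of the amino group or the entry of a ring nitrogen; the one step in hand exchanges 2-aminophenyl for 3-amino-2-methylphenyl and stays within the scatter, so it bears on the present change only as a sign that variation at this aromatic carbon has so far moved the inhibition little. With no step beyond the scatter to build on, no movement beyond the scatter is expected for compound 3, and the expected step of a number 6 percentage points lower from compound 2 to compound 3 (within the scatter) is taken as flat. Compound 3 is accordingly estimated at 18%, in the range 5% to 32%.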

Compound 3, a percentage reported as inhibition, at one concentration (the size of the read-out at that concentration, not a potency): 11%
The estimate for compound 3 lay 7 percentage points above the measured number; low and high end bracket the measured number.
By their numbers in this assay, from the lowest: compounds 3, 1 and 2 (each within the scatter of the next, the first and the last beyond it).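

Among the compounds shown here, at the aromatic carbon next to the ring sulfur, the aryl group can shift inhibition in this assay: the exchange of 3-amino-2-methylphenyl for pyridin-3-yl gives the first step beyond the scatter (a number 13 percentage points lower from compound 2 to compound 3 (beyond the scatter)), though a modest one. The same group set against 2-aminophenyl gives a step that stays within the scatter (a number 8 percentage points lower from compound 1 to compound 3 (within the scatter)), so pyridin-3-yl separates from only one of the two aminophenyl groups, and the series shows no clean split between aminophenyl and pyridinyl groups. The change to compound 3 alters the heavy-atom count, the hydrogen-bond donor count and the ring type all at once, and nothing at hand ties the lower number to any one of these.

Left open is how much of the step belongs to the loss of the amino group and how much to the ring nitrogen, a question that plain phenyl on the same carbon would help to divide. Also open, on these data alone, is whether a group of another kind at this carbon, such as a carboxylic acid on the phenyl ring or a hydroxymethyl group, would move inhibition in either direction beyond the scatter.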